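A few compounds are considered here, and "the series" means these few. Any claim that something is new, unique, unknown or untested is made for them only; others in the source may bear on it.

In a functional assay on HOS-TE85 cells (Homo sapiens) for inhibition, read by CCK-8 assay, with a stated time of 72 h (a higher number here means a weaker inhibitor, a lower number a stronger inhibitor), compound 1 (`COc1ccc(F)cc1N1C(=O)CSC1c1cccc(C(=O)NCCCCc2ccccc2)c1`) gives 8.8 nM, while compound 2 (`O=C(NCCCCc1ccccc1)c1cccc(C2SCC(=O)N2c2cccc(F)c2)c1`) gives 32.4 nM. Within the data shown here, compound 2 therefore has the higher of the two numbers, and compound 1 is its only neighbour on the scale. Compound 3 (`COc1cccc(OC)c1N1C(=O)CSC1c1cccc(C(=O)NCCCCc2ccccc2)c1`) has not yet been measured. It puts 2,6-dimethoxyphenyl in place of 3-fluorophenyl on an amide-type nitrogen in a ring. Among the measured compounds shown here, only one measured step bears on this change. Hydrogen in place of methoxy on an aromatic carbon gave a 3.7-fold higher number from compound 1 to compound 2 (0.57 log units; beyond the scatter), a modest step beyond the scatter. Read in reverse, that step from compound 2 back to compound 1 points to a lower number when methoxy is present, and compound 3 carries methoxy where compound 2 has none. For the measured compounds named here, no measured pair shows what a second methoxy group or the loss of fluorine does, so this single step is only a rough guide. The expected change is a 2.7-fold lower number from compound 2 to compound 3 (0.43 log units; beyond the scatter), a modest drop. For compound 3 the estimated value is 12 nM, with an expected range from 3 nM to 45 nM.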

Compound 3, half-maximal inhibitory concentration: > 1000 nM
Compound 3: no number, only a limit; the forecaster's own chance of this, stated with the estimate: 1%; middle value at least 83-fold (1.92 log units) away from the limit.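

In this assay compound 3 has no number, only a limit: the limit of > 1000 nM in this assay, at which 1 of the 3 values shown sits.

Putting 2,6-dimethoxyphenyl on the amide-type nitrogen in a ring gives an at least 30-fold higher number from compound 2 to compound 3 (1.48 log units; beyond the scatter) in place of 3-fluorophenyl, and it gives an at least 110-fold higher number from compound 1 to compound 3 (2.05 log units; beyond the scatter) in place of 5-fluoro-2-methoxyphenyl. Among these compounds, until now the only step at this nitrogen substituent was the modest one that linked a methoxy group to a lower number, whereas these two steps are large and show that the same position can lose nearly all activity in this assay; compound 3, with two methoxy groups, goes against any reading that methoxy on this phenyl ring lowers the number.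

Compound 3 gains a second methoxy group and lacks fluorine, and since these differences come together, the compounds shown do not tell which of them goes with the large rise, nor how far beyond its limit compound 3 lies. Going by these compounds, how this phenyl ring would read with a single methoxy group and no fluorine, or with a methyl group, a chlorine atom or an amine, also stays open.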